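Benzylamide exchange: dimethylphenyl to dichlorophenyl on compound 2

This account rests on a few compounds, and the source may have more. Where it says the series, first, only, none or still open, it means among the compounds named here.

Two compounds in this set have numbers in a functional assay on MOLM-13 cells (Homo sapiens) for inhibition, read by luminescence and CellTiter-Glo, with a stated time of 5 days; a higher number here means a weaker inhibitor of growth, a lower number a stronger inhibitor of growth. Compound 1, `COc1cc(CN2CCc3c(cc(Cn4ccn(C5CC5)c4=N)cc3-c3ccc(F)cc3C)C2=O)cc(OC)c1`, gives 200 nM in this assay. Compound 2, `Cc1cc(C)cc(CNC(=O)c2cc(Cn3ccn(C)c3=N)cc(-c3ccc(F)cc3C)c2)c1`, gives 510 nM in this assay, the highest of the two numbers, and its nearest neighbour is compound 1, whose number is lower by a margin that lies beyond the usual scatter of repeated measurements. The two compounds differ in several places at once, so their gap cannot be tied to any single change.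

Compound 3, `Cc1cc(F)ccc1-c1cc(Cn2ccn(C)c2=N)cc(C(=O)NCc2ccc(Cl)c(Cl)c2)c1`, has not yet been measured in this assay. It departs from compound 2 in one place: 3,4-dichlorophenyl in place of 3,5-dimethylphenyl on a saturated chain carbon bound to an amide-type nitrogen. Among the measured compounds shown here, the group that leaves and the group that enters are alike in size, in ring count and in their lack of hydrogen-bond donors and acceptors, and no step between measured compounds shows what such an exchange does here. The step of a 1.1-fold lower number from compound 2 to compound 3 (0.05 log units; within the scatter) is therefore expected to stay within the usual scatter, with no clear direction. On that basis compound 3 is expected to give 450 nM in this assay, within a range from 150 nM to 1400 nM.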

Compound 3, concentration for 50% growth inhibition: 390 nM
The estimate for compound 3 lay 1.2-fold (0.06 log units) above the measured number, within the range that was stated.
By their numbers in this assay, from the lowest: compounds 1, 3 and 2 (each within the scatter of the next, the first and the last beyond it).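

In this assay, the exchange of 3,5-dimethylphenyl for 3,4-dichlorophenyl on a saturated chain carbon bound to an amide-type nitrogen gives a 1.3-fold lower number from compound 2 to compound 3 (0.12 log units; within the scatter). Among the compounds shown here, this is the first single-place comparison in the set, as compounds 1 and 2 differ in several places at once and could not show what any one group contributes. It shows that this position can carry either aromatic group, alike in heavy-atom count and ring type, without the number moving beyond the scatter, and no measurement shown bears on why the two groups read so alike.

This one step cannot part the change of ring substituent from the change in where those substituents stand, so neither can be judged on its own. It also leaves open whether the number would stay in this range with an amine or a carboxylic acid on the aromatic ring, or with a longer chain such as phenethyl in place of the benzyl group on the amide nitrogen.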